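The compounds below may be only part of what the source reports. "The series", "measured", "known", "first", "only" and "open" are said of these compounds alone.

The shared core carries an aryl group on a saturated ring carbon. Compound 1 `N#CC1=C(N)OC(c2c[nH]c3ccccc23)=C(C#N)C1c1cccc2ccccc12` gives 7.7% in a functional assay, tested at 200 ug/mL; on this read-out lower numbers stand for a weaker effect and higher numbers for a stronger effect at the one concentration tested. Compound 2 `N#CC1=C(N)OC(c2c[nH]c3ccccc23)=C(C#N)C1c1ccccc1F` is reported in this assay only as "not active" (no number reported), so it stands without a single number and cannot be set beside compound 1 on the scale. Compound 3 `Cc1ccc(C2C(C#N)=C(N)OC(c3c[nH]c4ccccc34)=C2C#N)cc1` differs from compound 2 by 4-methylphenyl in place of 2-fluorophenyl on a saturated ring carbon. Among the compounds with values here, no measured step covers this change; with compound 1 at 7.7% and compound 2 without a number, no step beyond the scatter is expected in this assay in either direction. Compound 3 is expected to give 6% in this assay, within 0% to 18%.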

Compound 3, a percentage reported as activity, at one concentration (the size of the read-out at that concentration, not a potency): 6.2%
The estimate for compound 3 lay 0.2 percentage points below the measured number; the range from low to high includes it.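

this assay shows a number 1.5 percentage points lower from compound 1 to compound 3 (within the scatter) when 4-methylphenyl replaces naphthalen-1-yl on the saturated ring carbon, the first numerical comparison at this position, and it does not separate these two aryl groups. The change from 2-fluorophenyl to 4-methylphenyl cannot be read, as compound 2 has no single number. No supporting data bear on this result. Still open, on these data alone, is whether any group at this carbon gives a step beyond the scatter. A carboxylic acid or an amine on the phenyl ring would test this.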